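Ester truncation on the side chain: compound 2 to compound 4

The compounds below may be only part of what the source reports. "The series", "measured", "known", "first", "only" and "open" are said of these compounds alone.

The series shares one core carrying two benzyloxy groups and a side-chain ester. Compound 1 `O=C1C=C[C@@H](OCc2ccccc2)[C@@H]([C@@H](COC(=O)/C=C/c2ccccc2)OCc2ccccc2)O1` gives 13300 nM in a functional assay on A549 cells (Homo sapiens) for antiproliferative activity, read by MTT assay, with a stated time of 6 days; a higher number here means a weaker inhibitor, a lower number a stronger inhibitor. Compound 2 `O=C1C=C[C@@H](OCc2ccccc2)[C@@H]([C@@H](COC(=O)/C=C/c2ccc(F)cc2)OCc2ccccc2)O1` gives 12100 nM in this assay, and the step of a 1.1-fold lower number from compound 1 to compound 2 (0.04 log units; within the scatter) stays within the scatter. Compound 3 `COc1cccc(C(=O)OC[C@@H](OC(=O)c2cccc(OC)c2)[C@H]2OC(=O)C=C[C@H]2OC(=O)c2cccc(OC)c2)c1`, which differs from the others in several places at once, gives 18200 nM in this assay. Compound 2 therefore sits within the scatter of both compound 1 and compound 3; the three numbers do not separate.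

Compound 4 `CC(=O)OC[C@@H](OCc1ccccc1)[C@H]1OC(=O)C=C[C@H]1OCc1ccccc1` differs from compound 2 by methyl in place of 2-(4-fluorophenyl)ethenyl on a carbonyl carbon. Going by the values given here, no measured step touches this change: the single measured step concerns only the fluoro substituent on the aromatic ring, and compound 3 is not a one-place neighbour of any other compound. The change removes the whole cinnamate-type portion of the side-chain ester, leaving an acetoxy group, and nothing measured here speaks to the size or direction of such a step.

Among the compounds with values here, with no bearing step available, compound 4 is expected to fall near compound 2, with a wide range around it, so that the expected step of a 1.2-fold higher number from compound 2 to compound 4 (0.09 log units; within the scatter) is an estimate in this assay and not a prediction of direction. The estimate for compound 4 in this assay is 15000 nM, ranging from 5000 nM to 45000 nM.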

Compound 4, half-maximal inhibitory concentration: 15000 nM
The estimate for compound 4 equals the measured number at the digits printed, and the stated range covers the measured number.
By their numbers in this assay, from the lowest: compounds 2, 1, 4 and 3 (each within the scatter of the next).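

In this assay, going by these compounds alone, methyl in place of 2-(4-fluorophenyl)ethenyl on a carbonyl carbon reads as a 1.2-fold higher number from compound 2 to compound 4 (0.09 log units; within the scatter), the first reading at this position, where the earlier step concerned only the fluoro substituent on the aromatic ring. The matching change without fluorine, methyl in place of 2-phenylethenyl, reads as a 1.1-fold higher number from compound 1 to compound 4 (0.05 log units; within the scatter), so in both pairs the acetoxy compound does not separate from the larger ester, and the aromatic ring and double bond of that side chain are not needed to hold a number of this size in this assay. Nothing available explains why the numbers stay together across this change.

The compounds shown leave open whether the side-chain ester matters at all, since a free hydroxyl, a longer chain such as hexanoyl, or an acyl group carrying an amine would test this position beyond acetyl and the two cinnamate-type groups. They also leave open whether this flat reading holds on another substitution of the shared core, since both steps keep the two benzyloxy groups in place.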